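Swapping One Acetoxy Group for Hydrogen on Compound 2

The source may report more compounds than this note shows. Statements on the series, on what has been measured and on what is new or still open speak of the compounds shown alone.

Measured in a functional assay on SK-MEL cells (Homo sapiens) for cytotoxicity, read by MTT assay, with a stated time of 6 days; on this read-out higher numbers stand for an effect only at larger amounts of compound and lower numbers for an effect already at smaller amounts:
Compound 1 `COc1cc(OC)cc(-c2oc3ccccc3c(=O)c2C(=O)O)c1`: > 25 ug/mL
Compound 2 `CC(=O)Nc1ccc(-c2cc(=O)c3c(OC(C)=O)cc(OC(C)=O)cc3o2)cc1`: 14 ug/mL

The entry for compound 1 is a limit of the assay and not a number. Among the measured compounds shown here, compound 2, at 14 ug/mL, therefore holds the only true number in this small set, and no measured neighbour allows it to be ranked with any precision. For the measured compounds named here, the sole other reading is the limit of > 25 ug/mL in this assay, at which 1 of the 2 values shown sits.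

Compound 3 `CC(=O)Nc1ccc(-c2cc(=O)c3ccc(OC(C)=O)cc3o2)cc1` has yet to be tested. It differs from compound 2 in a single place, where hydrogen stands in place of acetoxy on an aromatic carbon: hydrogen in place of acetoxy on an aromatic carbon. The other acetoxy group and the rest of the structure stay as they are.

Going by the values given here, no measured pair in this set shows what a single change of this kind does in this assay, so the expectation stays modest: no shift beyond the usual scatter, with any drift more likely toward larger amounts. The expected change is a 1.1-fold higher number from compound 2 to compound 3 (0.06 log units; within the scatter). Compound 3 is expected at 16 ug/mL, with an estimated range of 7 ug/mL to 25 ug/mL.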

Compound 3, concentration for half-maximal effect: 16.9 ug/mL
Estimate against measurement, compound 3: 1.1-fold (0.02 log units) below; the measured number falls inside the stated range.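

In this assay, among the compounds shown here, replacing acetoxy with hydrogen gives the first measured single change in this set: a 1.2-fold higher number from compound 2 to compound 3 (0.08 log units; within the scatter). The acetoxy group on this aromatic carbon, meta to the remaining acetoxy group, can therefore be given up without a shift beyond the usual scatter, and compound 3, like compound 2, gives a true number and not a limit of the assay. This rests on one pair in one assay, and nothing in the data shown accounts for why the change leaves the reading within the scatter.

Going by these compounds, it remains open whether a hydroxyl group, a methoxy group or an amine on this same aromatic carbon would move the number beyond the scatter, or whether the outcome here is particular to the exchange of acetoxy for hydrogen. Also open is what the remaining acetoxy group contributes, since the effect of replacing it with hydrogen, or of replacing both acetoxy groups together, cannot be read from the compounds shown.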